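The source may report more compounds than this note shows. Statements on the series, on what has been measured and on what is new or still open speak of the compounds shown alone.

In an ADME assay on L929 cells (Mus musculus, culture collection number NCTC 929) for cytotoxicity, read by MTT assay, with a stated time of 72 h (on this read-out lower numbers stand for stronger inhibition and higher numbers for weaker inhibition), compound 1 `CCCCCCc1c(O)cc(C)oc1=O` reads > 200000 nM, which is a limit of the assay and not a number. Compound 2 `CCCCCCCCCCc1c(O)cc(C)oc1=O` gives 56000 nM, and compound 3 `CCCCCCCCCCCCCCc1c(O)cc(C)oc1=O` gives 24100 nM, the lower of the two numbers. Compound 4 `CCCCCCCCCCCCc1c(O)cc(C)oc1=O` differs from compound 3 by hydrogen in place of ethyl on a saturated chain carbon, ten or more bonds along the chain from an aromatic carbon, with hydrogen in place of ethyl on a saturated chain carbon, ten or more bonds along the chain from an aromatic carbon. Going by the values given here, two steps bear on this change, each adding butyl: an at least 3.5-fold lower number from compound 1 to compound 2 (0.55 log units; beyond the scatter) and a 2.3-fold lower number from compound 2 to compound 3 (0.37 log units; beyond the scatter). Compound 4 gives back only part of the chain added in a 2.3-fold lower number from compound 2 to compound 3 (0.37 log units; beyond the scatter), so in this assay a smaller rise, within the scatter, is expected. The expected step is a 1.5-fold higher number from compound 3 to compound 4 (0.17 log units; within the scatter). For compound 4 the estimated value is 36000 nM, with an expected range of 20000 nM to 65000 nM.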

Compound 4, half-maximal inhibitory concentration: 57200 nM
Compound 4: the middle estimate sits 1.6-fold (0.20 log units) below what was measured; measured number inside the range.
By their numbers in this assay, from the lowest: compound 3; then compounds 2 and 4 (each within the scatter of the next). At a limit, above all of these: compound 1.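

In this assay hydrogen in place of ethyl on a saturated chain carbon gives a 2.4-fold higher number from compound 3 to compound 4 (0.38 log units; beyond the scatter) and so undoes the earlier butyl step, while ethyl in place of hydrogen at that place gives a 1.0-fold higher number from compound 2 to compound 4 (0.01 log units; within the scatter) and changes nothing that can be read. Across compound 2, compound 4 and compound 3 the number does not follow chain length evenly: only the last ethyl shows a step beyond the scatter. Hexyl in place of hydrogen gives an at least 3.4-fold lower number from compound 1 to compound 4 (0.54 log units; beyond the scatter) as a step that starts from compound 1, whose reading is a limit and not a number: the limit of > 200000 nM in this assay, at which 1 of the 4 values shown sits.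

As far as these compounds go, whether a longer chain lowers the number further remains open, as does the effect of an amine or a carboxylic acid on this chain.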